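Alkoxy replacement on the shared core, compound 3 to compound 4

The source may report more compounds than this note shows. Statements on the series, on what has been measured and on what is new or still open speak of the compounds shown alone.

Measured so far:
compound 1 `CCNC(=O)c1cc(-c2ccc(NS(=O)(=O)c3cccc(Cl)c3Cl)cc2)nc2[nH]ncc12`; in an assay for inhibition of serine/threonine-protein kinase Sgk1 (Homo sapiens), with stated times of 30 min and 60 min, in the presence of a further agent that is not named here (on this read-out higher numbers stand for weaker inhibition and lower numbers for stronger inhibition), compound 1 gives 6 nM
compound 2 `CCOc1nc(-c2ccc(NS(=O)(=O)c3cc(Cl)ccc3F)cc2)nc2[nH]nc(C)c12`; in this assay compound 2 gives 23 nM
compound 3 `Cc1n[nH]c2nc(-c3ccc(NS(=O)(=O)c4cc(Cl)ccc4F)cc3)nc(OCCCO)c12`; in this assay compound 3 gives 2 nM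

Compound 3 gives the lowest number of the three in this assay; its steps to compound 1 and to compound 2 both lie beyond the scatter, so among these three it is the strongest inhibitor. Going by the values given here, compound 1 and compound 2 share no single-place step with each other, and their two values simply show compound 1 lower than compound 2.

The next compound, compound 4 `Cc1n[nH]c2nc(-c3ccc(NS(=O)(=O)c4cc(Cl)ccc4F)cc3)nc(OC3CC(C)(C)N(C)C(C)(C)C3)c12`, differs from compound 3 by 1,2,2,6,6-pentamethylpiperidin-4-yl in place of 3-hydroxypropyl on an oxygen on an aromatic ring. Among the compounds with values here, only one measured step bears on this position: a 12-fold lower number from compound 2 to compound 3 (1.06 log units; beyond the scatter). That step shows that extending the chain to carry a terminal hydroxyl lowered the number substantially. On these data alone, compound 4 gives up that chain together with its donor, which taken alone would point back toward a higher number; but a saturated six-membered ring with its own acceptor in this place is untested, so the expected size of the step is uncertain. On balance a moderate rise is expected, a 5.0-fold higher number from compound 3 to compound 4 (0.70 log units; beyond the scatter). For compound 4 the estimate in this assay is 10 nM, with a range from 2 nM to 50 nM.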

Compound 4, half-maximal inhibitory concentration: 2 nM
Compound 4: middle estimate off by 5.0-fold (0.70 log units), on the high side, within the range that was stated.
By their numbers in this assay, from the lowest: compounds 3 and 4 (each within the scatter of the next); then compound 1; then compound 2.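

In this assay, replacing 3-hydroxypropyl with the much larger, ring-bearing 1,2,2,6,6-pentamethylpiperidin-4-yl on the oxygen on an aromatic ring gives no change at the digits printed from compound 3 to compound 4 (within the scatter), so the low number at this position does not depend on the hydrogen-bond donor of the 3-hydroxypropyl group, which the entering group lacks. Set against the ethyl group of compound 2, the same ring gives a 12-fold lower number from compound 2 to compound 4 (1.06 log units; beyond the scatter), so among compounds 2, 3 and 4 two quite different groups on this oxygen share a low number and ethyl is the one that stands apart with the higher number. Nothing measured here accounts for why a flexible hydroxyl-bearing chain and a methylated saturated ring read alike in this assay.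

The compounds shown leave open whether the ring nitrogen matters, which a piperidin-4-yl group without its methyl groups or a cyclohexyl group would address. They also leave open whether the hydroxyl of the chain matters, since a propyl or 3-methoxypropyl group on the same oxygen would separate chain length from the hydroxyl.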